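The source may report more compounds than this note shows. Statements on the series, on what has been measured and on what is new or still open speak of the compounds shown alone.

For the measured compounds named here, compound 2 `COc1ccc(S(=O)(=O)N2CC(C(=O)N3CC(N)C3)c3ccccc32)c2ccccc12` holds the highest of the two numbers so far in a functional assay on CHO cells for antagonist activity at 5-hydroxytryptamine receptor 6 (Homo sapiens), read by FLIPR (a higher number here means a weaker inhibitor, a lower number a stronger inhibitor), giving 158 nM. The nearest is compound 1 `COc1ccc(S(=O)(=O)N2CC(C(=O)N(C)C3CCN(C)CC3)c3ccccc32)c2ccccc12`, which in this assay gives 7.94 nM. Going by the values given here, the only measured step, a 20-fold higher number from compound 1 to compound 2 (1.30 log units; beyond the scatter), replaces the whole amide substituent: 3-aminoazetidin-1-yl in place of methyl(1-methylpiperidin-4-yl)amino on a carbonyl carbon. Compound 3 `COc1ccc(S(=O)(=O)N2CC(C(=O)N3CC(CN)C3)c3ccccc32)c2ccccc12` is not yet measured. It differs from compound 2 by aminomethyl in place of amino on a saturated ring carbon of the four-membered non-aromatic ring with one nitrogen. The measured step is of a different kind, an exchange of the entire amide group, and offers no direct guide to a one-carbon extension of the amine. The step to compound 3 is therefore expected to be a 1.4-fold lower number from compound 2 to compound 3 (0.16 log units; within the scatter), within the scatter. Compound 3 is estimated at 110 nM in this assay, with a range of 30 nM to 400 nM.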

Compound 3, inhibition constant: 79.4 nM
Compound 3: middle estimate off by 1.4-fold (0.14 log units), on the high side; measured number inside the range.
By their numbers in this assay, from the lowest: compound 1; then compounds 3 and 2 (each within the scatter of the next).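

In this assay the change from amino to aminomethyl on the saturated ring carbon of the four-membered ring gives a 2.0-fold lower number from compound 2 to compound 3 (0.30 log units; within the scatter), so at this position compound 2 and compound 3 cannot be told apart and the added carbon is tolerated. The gap to the methyl(1-methylpiperidin-4-yl)amino amide remains with the longer amine, at a 10-fold higher number from compound 1 to compound 3 (1.00 log units; beyond the scatter), so the one-carbon extension does not bring the series back to the level of compound 1. No measured evidence bears on the origin of either step.

Open, from the compounds shown here alone, is whether a longer chain such as 2-aminoethyl, or a dimethylamino group, on that same ring carbon would stay within the scatter of compound 3. Also open, going by these compounds, is what a 4-aminopiperidin-1-yl group on the carbonyl carbon would give.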